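This account rests on a few compounds, and the source may have more. Where it says the series, first, only, none or still open, it means among the compounds named here.

Compound 1 `CCCCN(C)S(=O)(=O)NC(=O)Nc1c(C(C)C)cccc1C(C)C` gives 2300 nM in an assay on liver for inhibition of sterol O-acyltransferase 1 (Rattus norvegicus), using microsomes (a higher number here means a weaker inhibitor, a lower number a stronger inhibitor), and compound 2 `CC(C)c1cccc(C(C)C)c1OS(=O)(=O)NC(=O)OC1[C@H](C(C)C)CCC[C@H]1C(C)C` gives 5700 nM in this assay. Compound 3 `COc1cc(C(C)C)c(OC(=O)NS(=O)(=O)Oc2c(C(C)C)cccc2C(C)C)c(C(C)C)c1` is different: in this assay compound 3 reaches only a limit, > 25000 nM, so for compound 3 no number is known, only that it lies at the limit of > 25000 nM in this assay, at which 1 of the 3 values shown sits. Compound 4 `CC(C)c1cc(Cl)cc(C(C)C)c1OC(=O)NS(=O)(=O)Oc1c(C(C)C)cccc1C(C)C` differs from compound 3 in one place, chloro in place of methoxy on an aromatic carbon, meta to two isopropyl groups and para to a large group. Among the measured compounds shown here, no pair of measured compounds shows the effect of such a swap, so the expected step of a number no higher from compound 3 to compound 4 (the limit leaves the size open) is a small one, within the usual scatter, in no clear direction. Compound 4 is therefore estimated at 25000 nM, with a range from 8000 nM to 80000 nM.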

Compound 4, half-maximal inhibitory concentration: 42000 nM
Compound 4: the middle estimate sits 1.7-fold (0.23 log units) below what was measured; low and high end bracket the measured number.
By their numbers in this assay, from the lowest: compound 1; then compound 2; then compound 4.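

The step from compound 3 to compound 4 cannot be read, since compound 3 gives only a limit and not a number: the limit of > 25000 nM in this assay, at which 1 of the 4 values shown sits.

The compounds shown leave open how far chloro in place of methoxy on an aromatic carbon shifts the number in this assay.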